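The source may report more compounds than this note shows. Statements on the series, on what has been measured and on what is new or still open speak of the compounds shown alone.

Three compounds share one core. Compound 1 `CCNC(=O)[C@H]1O[C@@H](n2cnc3c(NNC(=O)c4ccc(Cl)cc4)ncnc32)[C@H](O)[C@@H]1O` and compound 2 `CCNC(=O)[C@H]1O[C@@H](n2cnc3c(NNC(=O)c4cccnc4)ncnc32)[C@H](O)[C@@H]1O` each carry a six-membered aromatic group on the carbonyl carbon, while compound 3 `CCNC(=O)[C@H]1O[C@@H](n2cnc3c(NNC(=O)c4ccco4)nc(Cl)nc32)[C@H](O)[C@@H]1O` carries furan-2-yl there and a chlorine on the core. In a functional assay on CHO cells for activation of adenosine receptor A2b (Homo sapiens), read by cAMP accumulation (a higher number here means that more compound is needed for the effect, a lower number that less compound is needed), compound 1 gives > 5000 nM, which is a limit of the assay and not a number. In this assay compound 2 likewise gives > 5000 nM, again a limit. The step that the two limits leave unreadable from compound 1 to compound 2 therefore cannot be read because the limit of > 5000 nM in this assay, at which 2 of the 3 values shown sit, is where both values sit. Among the measured compounds shown here, compound 3 gives 210 nM in this assay, and this is the only number among the three values shown.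

Compound 4 `CCNC(=O)[C@H]1O[C@@H](n2cnc3c(NNC(=O)c4sccc4C)nc(Cl)nc32)[C@H](O)[C@@H]1O` differs from compound 3 by 3-methylthiophen-2-yl in place of furan-2-yl on a carbonyl carbon. For the measured compounds named here, no measured step compares two numbers, so nothing measured bears on this change, and it is expected to be a step of a 1.1-fold lower number from compound 3 to compound 4 (0.02 log units; within the scatter), within the usual scatter. Compound 4 is therefore estimated at 200 nM, with a range from 70 nM to 700 nM.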

Compound 4, half-maximal effective concentration: 340 nM
For compound 4 the middle estimate is 1.7-fold (0.23 log units) below the measured one; low and high end bracket the measured number.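

In this assay, 3-methylthiophen-2-yl in place of furan-2-yl on the carbonyl carbon gives a 1.6-fold higher number from compound 3 to compound 4 (0.21 log units; within the scatter). Among the compounds shown here, this is the first step here that joins two numbers rather than limits, and it shows that, on the chlorine-bearing core, this position accepts a sulfur-containing ring with a methyl group in place of an oxygen-containing ring without a change beyond the scatter. Nothing on hand accounts for the size of this step.

The compounds shown leave open whether a six-membered aromatic group on the carbonyl carbon would behave the same way on the chlorine-bearing core. They also leave open what a group of another kind would do at this position, such as a propyl chain or a thiophene ring carrying an amine or a carboxylic acid.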